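The compounds below may be only part of what the source reports. "The series", "measured", "known", "first", "only" and "open" are said of these compounds alone.

Measured compounds:
compound 1 `O=C(O)C1CCN(c2ccccc2Cl)C1` — 19000 nM
compound 2 `Cc1cc(C(=O)O)c(C)n1-c1cccc(Cl)c1` — 430 nM
compound 3 `Cc1cc(C(=O)O)c(C)n1-c1cccc(Cl)c1Cl` — 220 nM

All three were run in an assay on cells for inhibition of Palmitoleoyl-protein carboxylesterase NOTUM variant C330S (Homo sapiens), read by fluorescence, with a stated time of 40 min; on this read-out higher numbers stand for weaker inhibition and lower numbers for stronger inhibition. Compound 1 gives the highest number of the three; compound 2 sits a long way lower, and compound 3 lower still. Compound 1 and compound 2 rest on different cores, and the difference between the two cores is not broken down here.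

Within the core of compound 2, one change is measured: chloro in place of hydrogen on an aromatic carbon It made the step of a 2.0-fold lower number from compound 2 to compound 3 (0.29 log units; within the scatter).

Compound 4 `O=C(O)C1CCN(c2cc(Cl)ccc2Cl)C1` is not yet measured. It differs from compound 1 by chloro in place of hydrogen on an aromatic carbon This is the same kind of change as that from compound 2 to compound 3, not the same: there the entering chloro sits ortho to a chloro group and ortho to a large group, here it sits meta to a group of 8 heavy atoms and para to a chloro group, and the core is a different one.

On that one precedent, a step of about a 1.9-fold lower number from compound 1 to compound 4 (0.28 log units; within the scatter) is expected, resting on a 2.0-fold lower number from compound 2 to compound 3 (0.29 log units; within the scatter). Compound 4 is estimated at 10000 nM, with 4000 nM to 25000 nM as the expected range.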

Compound 4, half-maximal inhibitory concentration: 7900 nM
The estimate for compound 4 lay 1.3-fold (0.10 log units) above the measured number; the measured number falls inside the stated range.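

In this assay, chloro in place of hydrogen on an aromatic carbon gives a 2.4-fold lower number from compound 1 to compound 4 (0.38 log units; beyond the scatter), a modest step that lies beyond the usual scatter. Set beside the earlier step on the other core, the change carries across in direction and in size: the same change on two cores in this assay, a 2.0-fold lower number (0.29 log units; within the scatter) from compound 2 to compound 3 and a 2.4-fold lower number (0.38 log units; beyond the scatter) from compound 1 to compound 4, 1.2-fold (0.09 log units) apart, within the scatter of two such steps

This rests on two pairs only, and the entering chloro stands in a different place in each, so the contribution of the core is not separated from that of the position, and nothing here shows that the step would hold on any further core.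

Open, as far as these compounds go, is whether fluoro or a nitrile on the same carbon would give a step of similar size on the core of compound 1. Also open, from the compounds shown here alone, is whether an amide in place of the carboxylic acid would retain inhibition on either core.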